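Swapping bromo for fluoro on the amide-side ring

The compounds below may be only part of what the source reports. "The series", "measured", "known", "first", "only" and "open" are said of these compounds alone.

Measured so far in a functional assay on HEK293 cells for agonist activity at probable G-protein coupled receptor 27 (Homo sapiens), read by a luciferase reporter and beta-arrestin recruitment, with a stated time of 10 min; a lower number here means a smaller maximal response, a higher number a larger maximal response:
compound 1 `O=C(Nc1ccc(S(=O)(=O)Nc2ccccc2)cc1)c1cc(F)c(Cl)cc1F` gives 37%;
compound 2 `O=C(Nc1ccc(S(=O)(=O)Nc2ccccc2)cc1)c1ccc(Br)cc1F` gives 67%;
compound 3 `O=C(Nc1ccc(S(=O)(=O)Nc2ccccc2)cc1)c1ccc(Cl)cc1Br` gives 123%.

Compound 3 stands highest of these three, with compound 2 next and compound 1 furthest down, both gaps beyond the scatter. Compound 4 `O=C(Nc1ccc(S(=O)(=O)Nc2ccccc2)cc1)c1ccc(Cl)cc1F` is the next step from compound 3: fluoro in place of bromo on an aromatic carbon, the ring otherwise unchanged.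

Going by the values given here, two measured steps bear on this change, though neither isolates it. The step of a number 56 percentage points higher from compound 2 to compound 3 (beyond the scatter) brings bromo in and fluoro out on this ring together with a swap of the second halogen, and the step of a number 86 percentage points higher from compound 1 to compound 3 (beyond the scatter) also brings bromo in where fluoro stood, alongside other changes. In both cases the arrival of bromo went with a large rise in this assay. Compound 4 undoes that arrival, and its ring differs from compound 2 only in the second halogen, so a large fall back towards compound 2 is expected, as a number 58 percentage points lower from compound 3 to compound 4 (beyond the scatter). The estimate for compound 4 in this assay is therefore 65%, with a range from 40% to 95%.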

Compound 4, largest response reached (Emax), in percent of the reference or control that the assay uses: 57%
Estimate against measurement, compound 4: 8 percentage points above; measured number inside the range.
By their numbers in this assay, from the lowest: compound 1; then compounds 4 and 2 (each within the scatter of the next); then compound 3.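

Going by these compounds alone, with the rest of the ring held fixed, this assay now isolates this swap: a number 66 percentage points lower from compound 3 to compound 4 (beyond the scatter) shows that fluoro in place of bromo at this position is enough on its own to bring a large change, which the earlier steps could not separate from changes elsewhere on the ring. The other halogen counts for far less when fluoro occupies this position, since a number 10 percentage points lower from compound 2 to compound 4 (within the scatter) leaves chloro and bromo there indistinguishable in this pair. A further ring change has a smaller but real effect: a number 20 percentage points higher from compound 1 to compound 4 (beyond the scatter) with hydrogen in place of fluoro on an aromatic carbon, so this position gives the largest single-place step among the compounds shown.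

From the compounds shown here alone, whether the high response is particular to bromo stays open, as chloro, iodo, methyl or methoxy at this position could fall on either side of the step, and the same goes for a plain hydrogen there. The data shown offer no measurement that accounts for the size of this step.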